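This account rests on a few compounds, and the source may have more. Where it says the series, first, only, none or still open, it means among the compounds named here.

The compounds measured so far:

Compound 1, `Cc1ncnc2c1c(I)cn2[C@@H]1O[C@H](CO)[C@@H](O)[C@H]1O`: in a functional assay on K562 cells (Homo sapiens), read by MTT assay, with a stated time of 72 h (a lower number here means a stronger inhibitor, a higher number a weaker inhibitor), compound 1 gives > 20000 nM, which is a limit of the assay and not a number.

Compound 2, `C#Cc1cn([C@@H]2O[C@H](CO)[C@@H](O)[C@H]2O)c2ncnc(C)c12`: in this assay compound 2 gives 110 nM.

Compound 3, `C#Cc1cn([C@@H]2O[C@H](CO)[C@@H](O)[C@H]2O)c2ncnc(OC)c12`: in this assay compound 3 gives 380 nM.

Compound 2 and compound 3 share a core that differs in one place: methoxy in place of methyl on an aromatic carbon. That change made a 3.5-fold higher number from compound 2 to compound 3 (0.54 log units; beyond the scatter). The other measured change runs from compound 2 to compound 1, (iodo in place of ethynyl on an aromatic carbon), and it made an at least 180-fold higher number from compound 2 to compound 1 (2.25 log units; beyond the scatter). The full size of that step is not known, because compound 1 sits at the limit of > 20000 nM in this assay, at which 1 of the 3 values shown sits.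

Compound 4, `COc1ncnc2c1c(I)cn2[C@@H]1O[C@H](CO)[C@@H](O)[C@H]1O`, has not yet been measured in this assay. It differs from compound 3 by iodo in place of ethynyl on an aromatic carbon, the same change as from compound 2 to compound 1, at a place described in the same words. For the measured compounds named here, the only guide to it is the measured step of an at least 180-fold higher number from compound 2 to compound 1 (2.25 log units; beyond the scatter). Compound 3 starts from a higher number than compound 2, so if the change acts alike, compound 4 is expected to reach or pass the limit of the assay. Compound 4 is therefore expected near 30000 nM, within 8000 nM to 100000 nM. Going by the values given here, that estimate means an expected step of a 79-fold higher number from compound 3 to compound 4 (1.90 log units; beyond the scatter), resting on the single earlier instance of this change.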

Compound 4, half-maximal inhibitory concentration: 14800 nM
Beside the measured number, compound 4's estimate is 2.0-fold (0.31 log units) above it, and the stated range covers the measured number.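

In this assay, iodo in place of ethynyl again gave a much weaker compound when the core carried methoxy instead of methyl, with a 39-fold higher number from compound 3 to compound 4 (1.59 log units; beyond the scatter), so on these two cores the direction carried over and the step stayed large, but its size did not carry over exactly: the same change on two cores in this assay, an at least 180-fold higher number (2.25 log units; beyond the scatter) from compound 2 to compound 1 and a 39-fold higher number (1.59 log units; beyond the scatter) from compound 3 to compound 4, at least 4.6-fold (0.66 log units) apart, beyond the scatter of two such steps. The methoxy for methyl change transferred less well, since its step on the ethynyl compounds, a 3.5-fold higher number from compound 2 to compound 3 (0.54 log units; beyond the scatter), does not match its step on the iodo compounds, an at least 1.3-fold lower number from compound 1 to compound 4 (0.13 log units; that floor lies within the scatter): the same change on two cores in this assay, a 3.5-fold higher number (0.54 log units; beyond the scatter) from compound 2 to compound 3 and an at least 1.3-fold lower number (0.13 log units; that floor lies within the scatter) from compound 1 to compound 4, at least 4.6-fold (0.66 log units) apart, beyond the scatter of two such steps. As far as these compounds go, compound 1 gives > 20000 nM, which is a limit of the assay and not a number, so the full size of both steps that touch it remains unknown, and two cores show nothing about how either change would behave on a third.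

The compounds shown leave open whether a different group on this aromatic carbon, such as chloro, a nitrile or a longer alkyne chain, would stay close to ethynyl or fall towards iodo. They also leave open what an amine in place of methyl or methoxy would do on the ethynyl core.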